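This account rests on a few compounds, and the source may have more. Where it says the series, first, only, none or still open, it means among the compounds named here.

Compound 3 `O=C(O)CCc1ccc(C#Cc2ccncc2)cc1` gives 100% in an in vitro functional assay on 1321-N1 cells for agonist activity at Free fatty acid receptor 1 (Homo sapiens), read by fluorescence, spectrophotometry and calcium flux (a higher number here means a larger maximal response, a lower number a smaller maximal response), the highest of the three numbers shown, though neither of the other two lies beyond the scatter: compound 1 `O=C(O)CCc1ccc(C#Cc2cccnc2)cc1` gives 96% and compound 2 `O=C(O)CCc1ccc(C#Cc2ccnc(Oc3ccccc3)c2)cc1` gives 94%. The step of a number 4 percentage points higher from compound 1 to compound 3 (within the scatter) and the step of a number 6 percentage points higher from compound 2 to compound 3 (within the scatter) both stayed within the scatter. Compound 4 `Cc1ccsc1C#Cc1ccc(CCC(=O)O)cc1` differs from compound 3 by 3-methylthiophen-2-yl in place of pyridin-4-yl on a triple-bonded carbon. For the measured compounds named here, only the step of a number 4 percentage points higher from compound 1 to compound 3 (within the scatter) touches the same triple-bonded carbon, and it moved the maximal response by little, so no step beyond the scatter is expected in this assay in either direction. Compound 4 is therefore estimated to give 96%, in a range from 82% to 108%, which is an expected step of a number 4 percentage points lower from compound 3 to compound 4 (within the scatter).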

Compound 4, largest response reached (reported as efficacy), in percent of the reference or control that the assay uses: 100%
For compound 4 the middle estimate is 4 percentage points below the measured one, and the stated range covers the measured number.
By their numbers in this assay, from the lowest: compounds 2, 1, 3 and 4 (each within the scatter of the next).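

In this assay, a five-membered sulfur ring carrying a methyl group, 3-methylthiophen-2-yl, replaces the six-membered nitrogen rings on the triple-bonded carbon, with no change at the digits printed from compound 3 to compound 4 (within the scatter) and a number 4 percentage points higher from compound 1 to compound 4 (within the scatter) as the steps. The earlier compounds shown here carried only pyridine rings at this place, so the full response is now seen to need neither a ring nitrogen nor a six-membered ring here. No measurement given here explains this tolerance. Going by these compounds, whether it extends to a saturated cyclohexyl ring or an amine on the triple-bonded carbon stays open.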